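Outlook for compound 4

The source may hold more compounds than are shown below. What is called first, only, known or untested is meant among the compounds shown, and "the series" means these compounds.

Compound 1 `Cc1cc(C)c(NC(=O)c2sccc2S(=O)(=O)Nc2onc(C)c2Cl)c(C)c1` gives 81600 nM in an in vivo ADME assay on the whole organism (plasma) for pharmacokinetics, with Rattus norvegicus as the target, at a dose of 50 mg/kg by the oral route (on this read-out lower numbers stand for lower exposure and higher numbers for higher exposure at the dose given), the highest of the three numbers measured. Compound 2 `Cc1cc(C)c(S(N)(=O)=O)c(C)c1NC(=O)c1sccc1S(=O)(=O)Nc1onc(C)c1Cl` gives 5590 nM and compound 3 `Cc1cc(C)c(NC(=O)c2sccc2S(=O)(=O)Nc2onc(C)c2Cl)c(C)c1C#N` gives 37200 nM. The steps from the parent are a 15-fold lower number from compound 1 to compound 2 (1.16 log units; beyond the scatter) and a 2.2-fold lower number from compound 1 to compound 3 (0.34 log units; beyond the scatter), and between the two analogues stands a 6.7-fold higher number from compound 2 to compound 3 (0.82 log units; beyond the scatter). Compound 4 `Cc1cc(C)c(NC(=O)c2sccc2S(=O)(=O)Nc2onc(C)c2Cl)c(-c2ncco2)c1` differs from compound 1 in one place: 1,3-oxazol-2-yl in place of methyl on an aromatic carbon. Both measured steps bear on it, since each put a new group onto an aromatic carbon of the same ring and each lowered the number beyond the scatter. A lowering of modest size is therefore expected here; the step expected is a 3.3-fold lower number from compound 1 to compound 4 (0.51 log units; beyond the scatter). Compound 4 is estimated to give 25000 nM, within 8000 nM to 70000 nM.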

Compound 4, maximal plasma concentration: 134000 nM
Estimate against measurement, compound 4: 5.4-fold (0.73 log units) below; the measured number lies above the stated range.
By their numbers in this assay, from the lowest: compound 2; then compound 3; then compounds 1 and 4 (each within the scatter of the next).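

In this assay 1,3-oxazol-2-yl in place of methyl gives a 1.6-fold higher number from compound 1 to compound 4 (0.22 log units; within the scatter) and so shows that this aromatic carbon, ortho to a large group, accepts a five-membered aromatic ring with no change beyond the scatter. Compound 2 and compound 3 both went lower, so a new group on this ring does not lower the number in every case. No measured evidence accounts for this result. As far as these compounds go, whether an amine or a carboxylic acid on this carbon would also stay within the scatter of compound 1 remains open.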